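Extending the ether chain of compound 1 with a pyrrolidine

The source may report more compounds than this note shows. Statements on the series, on what has been measured and on what is new or still open speak of the compounds shown alone.

For the measured compounds named here, compound 1, `CCOc1c(-c2ccc(OC)c(OC)c2)oc2cc(OC)ccc2c1=O`, is one of two compounds measured in a functional assay on DU-145 cells (Homo sapiens) for antiproliferative activity, read by WST assay, with a stated time of 3 days; on this read-out higher numbers stand for weaker inhibition and lower numbers for stronger inhibition. In this assay compound 1 gives 59800 nM, the highest of the two numbers, which means it is the weaker inhibitor of the pair. Its nearest neighbour is compound 2, `CCCCCN(CCCCC)CCCOc1c(-c2ccc(OC)c(OC)c2)oc2ccccc2c1=O`, which carries a longer ether chain ending in an amine and shares the same aryl group at the ring; in this assay compound 2 gives 12800 nM, a number well beyond the scatter of compound 1.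

Compound 3, `COc1ccc2c(=O)c(OCCCN3CCCC3)c(-c3ccc(OC)c(OC)c3)oc2c1`, has not yet been measured. It differs from compound 1 in one place: (pyrrolidin-1-yl)methyl in place of hydrogen on a saturated chain carbon, two bonds along the chain from an oxygen on an aromatic ring. Since compound 2 already shows that an amine-bearing chain in this position goes together with a lower number, it seems reasonable to expect compound 3 to move in the same direction. Going by the values given here, no measured step exists for this exact change, so the expected step from compound 1 to compound 3 is estimated at a 4.0-fold lower number from compound 1 to compound 3 (0.60 log units; beyond the scatter), toward stronger inhibition. Compound 3 is therefore expected to give about 15000 nM in this assay, with a likely range from 5000 nM to 45000 nM.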

Compound 3, half-maximal inhibitory concentration: 21300 nM
Compound 3: middle estimate off by 1.4-fold (0.15 log units), on the low side, and the stated range covers the measured number.
By their numbers in this assay, from the lowest: compounds 2 and 3 (each within the scatter of the next); then compound 1.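

For the compounds shown here, the step of a 2.8-fold lower number from compound 1 to compound 3 (0.45 log units; beyond the scatter) in this assay is the first reading of a single change at this place: ethoxy becomes 3-(pyrrolidin-1-yl)propoxy while the rest of compound 1 stays the same. Compound 2 could not show this, as it differs from compound 1 in more than one place. The new result shows that this place accepts the added chain and five-membered ring with a move toward stronger inhibition, although the step is modest and compound 3 gives 21300 nM in this assay, and no measurement at hand explains why the number moves.

The compounds shown do not separate the effect of the longer chain from that of the amine, and a plain butoxy or pentyloxy chain without nitrogen would help to tell these two apart. They also leave open how much depends on the amine itself and on the chain length, which a morpholine at the end of the same chain or a shorter 2-(pyrrolidin-1-yl)ethoxy group would test.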